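The source may report more compounds than this note shows. Statements on the series, on what has been measured and on what is new or still open speak of the compounds shown alone.

Measured compounds:
- compound 1, `O=C(NO)c1ccc(Cn2nnc(Cc3ccccc3)n2)cc1` — 52 nM in an assay on Sf9 cells for inhibition of protein deacetylase HDAC6 (Homo sapiens), read by fluorescence; on this read-out higher numbers stand for weaker inhibition and lower numbers for stronger inhibition
- compound 2, `O=C(NO)c1ccc(Cn2nnc(-c3ccc(S(F)(F)(F)(F)F)cc3)n2)cc1` — 25 nM in this assay

Compound 1 holds the higher of the two numbers in this assay; compound 2 sits lower, and that gap lies beyond the usual scatter. Among the measured compounds shown here, no pair of measured compounds differs in a single place, so no clean step is available.

Compound 3, `O=C(NO)c1ccc(Cn2nnc(-c3ncccn3)n2)cc1`, has not yet been measured in this assay. Against compound 1 the change is pyrimidin-2-yl in place of benzyl on an aromatic carbon. Compound 2 also carries a ring joined directly to the shared core, yet it differs from compound 1 in more than one place, so its value does not isolate this change. With nothing closer to go on, the expectation for compound 3 is a step of a 1.5-fold higher number from compound 1 to compound 3 (0.19 log units; within the scatter), leaning toward a higher number but not beyond the scatter. Compound 3 is estimated at 80 nM, with a range from 20 nM to 300 nM.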

Compound 3, half-maximal inhibitory concentration: 7 nM
Estimate against measurement, compound 3: 11-fold (1.06 log units) above; measured number below the stated range.
By their numbers in this assay, from the lowest: compound 3; then compound 2; then compound 1.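

In this assay the aromatic carbon between two ring nitrogen atoms proves sensitive to its substituent: pyrimidin-2-yl in place of benzyl gives a 7.4-fold lower number from compound 1 to compound 3 (0.87 log units; beyond the scatter) and this first single-place step in the series lies beyond the scatter. The step also shows that a benzyl group is not needed at this position for a low number, and that a six-membered aromatic ring with 2 hetero atoms is accepted there. Nothing at hand accounts for the size of this step.

Among the compounds shown here, the single step changes two things at once, the carbon link of the benzyl group and the ring nitrogen atoms, so their separate contributions remain open. An unsubstituted phenyl or a pyridin-2-yl group on this carbon would pull the two apart.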